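Sulfonylamino in place of phenoxy: expectation for compound 4

The source may hold more compounds than are shown below. What is called first, only, known or untested is meant among the compounds shown, and "the series" means these compounds.

Values so far in a functional assay on HepG2 cells (Homo sapiens) for antiproliferative activity, read by MTT assay, with a stated time of 48 h (a higher number here means a weaker inhibitor, a lower number a stronger inhibitor), are:
- compound 1 `COc1ccc(CN(C(=O)Cn2cc(COc3ccccc3)nn2)c2cc(OC)c(OC)c(OC)c2)cc1` at 20500 nM in this series
- compound 2 `COc1ccc(CN(C(=O)Cn2cc(CSc3nc4ccccc4s3)nn2)c2cc(OC)c(OC)c(OC)c2)cc1` at 49200 nM in this series
- compound 3 `COc1ccc(CN(C(=O)Cn2cc(CNS(=O)(=O)c3ccc(C)cc3)nn2)c2cc(OC)c(OC)c(OC)c2)cc1` at 30500 nM in this series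

Compound 1 sits at the low end of these numbers, level within the scatter with compound 3. The change to compound 4 `COc1ccc(CN(C(=O)Cn2cc(CNS(=O)(=O)c3ccc(Br)cc3)nn2)c2cc(OC)c(OC)c(OC)c2)cc1` is ((4-bromophenyl)sulfonyl)amino in place of phenoxy on a saturated chain carbon bound to an aromatic carbon on the same chain carbon. The closest guide is a 1.5-fold higher number from compound 1 to compound 3 (0.17 log units; within the scatter) with ((4-methylphenyl)sulfonyl)amino entering, a step within the scatter. The other replacement shows a 2.4-fold higher number from compound 1 to compound 2 (0.38 log units; beyond the scatter) and is modest. Within the data shown here, no measured pair tests bromine against methyl. The expected step in this assay is a 1.4-fold higher number from compound 1 to compound 4 (0.14 log units; within the scatter) upward and not beyond the scatter. For compound 4 the estimated value is 28000 nM with an expected range from 13000 nM to 60000 nM in this assay.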

Compound 4, half-maximal inhibitory concentration: 7370 nM
The estimate for compound 4 lay 3.8-fold (0.58 log units) above the measured number, outside the stated range (below it).
By their numbers in this assay, from the lowest: compound 4; then compounds 1, 3 and 2 (each within the scatter of the next, the first and the last beyond it).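

In this assay, the aromatic substituent of the sulfonylamino group proves to matter: bromo in place of methyl on an aromatic carbon separates the two sulfonamides beyond the scatter (a 4.1-fold lower number from compound 3 to compound 4 (0.62 log units; beyond the scatter)). Unlike the methyl-bearing group, ((4-bromophenyl)sulfonyl)amino also improves on phenoxy (a 2.8-fold lower number from compound 1 to compound 4 (0.44 log units; beyond the scatter)) and on (1,3-benzothiazol-2-yl)sulfanyl (a 6.7-fold lower number from compound 2 to compound 4 (0.82 log units; beyond the scatter)). No measurement at hand accounts for this gain. On these data alone, whether it is specific to bromine remains open. A chloro, methoxy or carboxylic acid group on the same aromatic carbon could side with either compound 3 or compound 4.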